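A few compounds are considered here, and "the series" means these few. Any claim that something is new, unique, unknown or untested is made for them only; others in the source may bear on it.

Working notes on the antiproliferative series. The reference point is compound 2, `CSc1cnc2ccccc2c1[Se]CC#CCO`, which in a functional assay on CCRF-CEM cells (Homo sapiens) for antiproliferative activity, with a stated time of 72 h (a higher number here means a weaker inhibitor, a lower number a stronger inhibitor), gives 0.5 ug/mL. Within the data shown here, this is the lowest of the three numbers so far. Its benzoate, compound 3, `CSc1cnc2ccccc2c1[Se]CC#CCOC(=O)c1ccccc1`, gives 1.9 ug/mL in this assay, the step being a 3.8-fold higher number from compound 2 to compound 3 (0.58 log units; beyond the scatter). Compound 1, `ClCC#CCSc1cnc2ccccc2c1Cl`, carries the chloro-substituted butynyl thioether on a core bearing chlorine where compound 2 has the methylsulfanyl group. In this assay compound 1 gives 3.7 ug/mL. Among the measured compounds shown here, no single-point step from compound 1 to compound 2 exists, so the two values are only set side by side.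

Compound 4, `CSc1cnc2ccccc2c1SCC#CCCl`, is the unmeasured member. It differs from compound 2 as follows: a group of 6 heavy atoms (4 carbon, 1 sulfur, 1 chlorine; no ring) in place of a group of 6 heavy atoms (4 carbon, 1 oxygen, 1 selenium; no ring), on an aromatic carbon. The hydroxyl is lost and the selenium is exchanged for sulfur, both within the chain on the aromatic carbon opposite the ring nitrogen.

Bearing on this: the only measured step in the set, from compound 2 to compound 3, removed the free hydroxyl and raised the number by a modest amount, beyond the scatter. For the measured compounds named here, compound 4 also loses the hydroxyl, and compound 1, the only other compound with this chloro-terminated chain, sits well above compound 2. An upward step beyond the scatter is therefore expected, of a size comparable to or somewhat larger than the benzoate step, giving a 4.0-fold higher number from compound 2 to compound 4 (0.60 log units; beyond the scatter) for the move to compound 4. The estimate for compound 4 in this assay is 2 ug/mL, with a range from 0.8 ug/mL to 5 ug/mL.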

Compound 4, concentration for 50% inhibition: 2.5 ug/mL
The estimate for compound 4 lay 1.3-fold (0.10 log units) below the measured number; low and high end bracket the measured number.
By their numbers in this assay, from the lowest: compound 2; then compounds 3, 4 and 1 (each within the scatter of the next).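

In this assay, the chain on the aromatic carbon opposite the ring nitrogen can now be read on the core of compound 2 with a chloro-terminated sulfur chain in place of the hydroxy-terminated selenium chain: a 5.0-fold higher number from compound 2 to compound 4 (0.70 log units; beyond the scatter). Alongside a 3.8-fold higher number from compound 2 to compound 3 (0.58 log units; beyond the scatter), this gives two changes of different kinds at the chain, both of which lose the free hydroxyl and both of which give a higher number beyond the scatter, with compound 3 and compound 4 within the scatter of each other, so among compounds 2, 3 and 4 only the free hydroxyl compound stands apart, and none of the three goes against this. Nothing available explains the step, and no measurement bears on its cause.

The step to compound 4 changes the chalcogen and the chain end together, so what selenium contributes and what the hydroxyl contributes cannot be separated from these compounds. Also open, going by these compounds, is how the number responds to a different chain end on the selenium chain, such as an amine or a carboxylic acid, or to a longer chain at this aromatic carbon.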